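N-Methylation of a Piperidine Oxime Ether Series

The source may report more compounds than this note shows. Statements on the series, on what has been measured and on what is new or still open speak of the compounds shown alone.

Measured so far:
Compound 1, `CO/N=C1\C[C@@H](c2ccc(F)cc2)N[C@@H](c2ccc(F)cc2)[C@@H]1C`, 49200 nM in a functional assay on HeLa cells (Homo sapiens) for inhibition, read by MTT assay, with a stated time of 24 h; a lower number here means a stronger inhibitor, a higher number a weaker inhibitor.
Compound 2, `CCOc1ccc([C@H]2N[C@@H](c3ccc(OCC)cc3)[C@H](C)/C(=N/OC)[C@@H]2C)cc1`, 98000 nM in this assay.

The two values lie within the usual scatter of each other, so compound 1 cannot be set ahead of or behind compound 2 in this assay. Compound 3, `CO/N=C1\C[C@@H](c2ccc(F)cc2)N(C)[C@@H](c2ccc(F)cc2)[C@@H]1C`, is not yet measured. It differs from compound 1 by methyl in place of hydrogen on an amine nitrogen in a ring. Within the data shown here, no measured pair in this set shows what such a change does, so nothing beyond the scatter is expected in either direction. The estimate for compound 3 in this assay is 50000 nM, with a range from 18000 nM to 140000 nM, a step of a 1.0-fold higher number from compound 1 to compound 3 (0.01 log units; within the scatter).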

Compound 3, half-maximal inhibitory concentration: 40700 nM
For compound 3 the middle estimate is 1.2-fold (0.09 log units) above the measured one, and the stated range covers the measured number.
By their numbers in this assay, from the lowest: compounds 3, 1 and 2 (each within the scatter of the next, the first and the last beyond it).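

In this assay, methyl in place of hydrogen on an amine nitrogen in a ring gives a 1.2-fold lower number from compound 1 to compound 3 (0.08 log units; within the scatter) and so provides the first step read at this position. Here, the ring nitrogen of the core of compound 1 takes a methyl group with no difference beyond the scatter. Nothing available bears on why this is so.

As far as these compounds go, whether a longer chain such as ethyl, or an acetyl group, on the same nitrogen would also stay within the scatter remains open. So does the effect of this methyl on the core of compound 2.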